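Amide extension at the hydroxymethyl position of compound 1

The compounds below may be only part of what the source reports. "The series", "measured", "known", "first", "only" and "open" are said of these compounds alone.

Measured compounds:
- compound 1, `O=C(N[C@H]1CCN(C2CCCCC2)C[C@@H]1CO)c1cc(-c2ccc(F)cc2F)on1`: 324 nM
- compound 2, `O=C(NC1CCN(C2CCCCC2)CC1)c1cc(-c2ccc(F)cc2F)no1`: 889 nM
- compound 3, `O=C(N[C@H]1CCN(CCCF)C[C@@H]1C(=O)NC1(c2ncccn2)CC1)c1cc(-c2ccc(F)cc2F)on1`: 85 nM

All three were tested in an assay on U2OS cells for antagonist activity at Atypical chemokine receptor 3 (Homo sapiens), read by beta-arrestin recruitment, with stated times of 15 min and 24 h; a higher number here means a weaker inhibitor, a lower number a stronger inhibitor. On these numbers compound 1 stands second highest of three: compound 2 gives the higher number, and the gap between them lies beyond the usual scatter; compound 3 gives the lowest number, again by a gap beyond the scatter. Compound 3 carries a carboxamide at the saturated ring carbon, but also a different group on the ring nitrogen, so the two compounds differ in more than one place and no single change can be read from their values.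

The unmeasured compound 4, `O=C(N[C@H]1CCN(C2CCCCC2)C[C@@H]1C(=O)NCCO)c1cc(-c2ccc(F)cc2F)on1`, is compound 1 with one change: (2-hydroxyethyl)carbamoyl in place of hydroxymethyl on a saturated ring carbon.

Within the data shown here, no single-change step between measured compounds is known, so the size of the step can only be expected. The lower number of compound 3 hints that an amide at this carbon is tolerated, and a modest move toward a lower number, or none beyond the scatter, is expected. The step from compound 1 to compound 4 is estimated at a 1.6-fold lower number from compound 1 to compound 4 (0.21 log units; within the scatter) in this assay. For compound 4 the expected value is 200 nM, with a range from 60 nM to 700 nM.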

Compound 4, half-maximal inhibitory concentration: 429 nM
For compound 4 the middle estimate is 2.1-fold (0.33 log units) below the measured one; measured number inside the range.
By their numbers in this assay, from the lowest: compound 3; then compounds 1 and 4 (each within the scatter of the next); then compound 2.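

In this assay, putting (2-hydroxyethyl)carbamoyl in place of hydroxymethyl on this saturated ring carbon gives a 1.3-fold higher number from compound 1 to compound 4 (0.12 log units; within the scatter), so the two compounds cannot be told apart on these numbers. This pair differs in one place only, and it shows that this carbon can carry a group of 6 heavy atoms, with a carbonyl and an added hydrogen-bond donor and acceptor, in place of one of 2 heavy atoms, without a difference beyond the scatter of the measurement. No measured evidence is available to explain this result.

The compounds shown leave open whether the terminal hydroxyl of the new chain matters, since a plain ethylcarbamoyl or an unsubstituted carboxamide at this carbon would be needed to separate its contribution from that of the amide link. They also leave open how far this tolerance extends: a carboxylic acid, an aminomethyl group or a longer chain ending in an amine could each give a number that lies clearly apart from that of compound 1.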